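The source may report more compounds than this note shows. Statements on the series, on what has been measured and on what is new or still open speak of the compounds shown alone.

Measured compounds:
- compound 1 `CCOC(=O)c1sc2nc(C3CC3)cc(C(F)(F)F)c2c1N`: > 20000 nM
- compound 2 `Nc1c(C(=O)O)sc2nc(-c3ccccc3)cc(C(F)(F)F)c12`: > 20000 nM

In an ADME assay on Huh-7 cells (Homo sapiens) for cytotoxicity, read by MTT assay, with a stated time of 72 h (on this read-out higher numbers stand for lower toxicity in this test and lower numbers for higher toxicity in this test), compound 1 gives > 20000 nM, which is a limit of the assay and not a number. Compound 2 gives > 20000 nM in this assay, again a limit rather than a number. Compound 2 therefore stands at the limit, and both of the two values shown sit there, as stated by the limit of > 20000 nM in this assay, at which 2 of the 2 values shown sit. Going by the values given here, no step between two measured compounds is available.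

Compound 3 `CCN(CC)C(=O)c1sc2nc(-c3ccccc3)cc(C(F)(F)F)c2c1N` differs from compound 2 by diethylamino in place of hydroxy on a carbonyl carbon; one bond further out, the change reads carboxy to diethylcarbamoyl. Among the compounds with values here, no measured step addresses this change. Compound 3 is expected to remain at the limit, with a step that the limit leaves unreadable from compound 2 to compound 3 that amounts to none beyond the scatter. Compound 3 is estimated at 30000 nM, with a range from 10000 nM to 100000 nM.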

Compound 3, half-maximal cytotoxic concentration: > 100000 nM
Compound 3: a limit, no number; the forecaster's own chance of this, stated with the estimate: 70%; middle value at least 3.3-fold (0.52 log units) from the limit.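

In this assay compound 3 gives > 100000 nM, which is a limit of the assay and not a number. Compound 2 also stands at a limit, and no step can be read between compound 2 and compound 3. The compounds shown leave open at what concentration any of them becomes cytotoxic in this test.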